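A few compounds are considered here, and "the series" means these few. Any claim that something is new, unique, unknown or untested is made for them only; others in the source may bear on it.

Of the compounds shown here, two have been measured in a functional assay on MDA-MB-435 cells (Homo sapiens) for inhibition; a lower number here means a stronger inhibitor, a higher number a weaker inhibitor. Compound 1, with structure `O=C(/C=C/c1ccc(B(O)O)cc1)c1ccc[nH]1`, gives 15000 nM in this assay. Compound 2, with structure `O=C(O)COc1ccc(C(=O)/C=C/c2ccc(Cl)c(Cl)c2)cc1`, gives 9000 nM in this assay. These two numbers lie within the usual scatter of each other, so neither compound can be set apart from the other on the evidence at hand, and compound 1 simply stands alongside compound 2 as one of two comparably weak inhibitors.

The next compound to be examined is compound 3, with structure `O=C(/C=C/c1ccccc1)c1ccc[nH]1`. It differs from compound 1 in one place only: a hydrogen atom in place of a group of 3 heavy atoms (1 boron, 2 oxygen; no ring), on an aromatic carbon. The boron-bearing group of compound 1 is thereby stripped away and nothing but a hydrogen atom remains at that aromatic carbon.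

For the measured compounds named here, no pair of measured compounds differing in one place is available, so the size of this kind of change in this assay is not known from the data. The step from compound 1 to compound 3 is estimated as a 1.5-fold higher number from compound 1 to compound 3 (0.17 log units; within the scatter), which is a modest loss of potency, though a result within the scatter would not be surprising. Compound 3 is therefore expected to give about 22000 nM in this assay, with a plausible range from 6000 nM to 80000 nM.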

Compound 3, half-maximal inhibitory concentration: 15000 nM
Compound 3: the middle estimate sits 1.5-fold (0.17 log units) above what was measured; low and high end bracket the measured number.
By their numbers in this assay, from the lowest: compounds 2, 1 and 3 (each within the scatter of the next).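

In this assay, putting a hydrogen atom in place of the boron-bearing group of 3 heavy atoms gives no change at the digits printed from compound 1 to compound 3 (within the scatter) on this aromatic carbon. For the compounds shown here, this is the first one-place comparison in the set, and it shows that the boron-bearing group is not needed for the weak inhibition seen with compound 1, since compound 3 lacks that group and reads the same. No measured evidence here explains why the two compounds read alike.

This single pair says nothing about other replacements at this aromatic carbon, so an amine, a carboxylic acid or a methoxy group there could still give a clearly different number. It also cannot show whether this position matters at all to the inhibition, or whether the same swap would give the same result on a different core, such as that of compound 2.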